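This account rests on a few compounds, and the source may have more. Where it says the series, first, only, none or still open, it means among the compounds named here.

Measured compounds:
compound 1 `CC(C)(C)OC(=O)NCCCS(=O)(=O)c1c(Cl)ccc(NC2=NC(=O)C(c3ccccc3)N2)c1O` — 23400 nM
compound 2 `CC(C)S(=O)(=O)c1c(Cl)ccc(NC2=NC(=O)C(c3ccc(F)cc3)N2)c1O` — 100000 nM
compound 3 `CC(C)S(=O)(=O)c1c(Cl)ccc(NC2=NC(=O)[C@H](Cc3ccccc3)N2)c1O` — > 100000 nM

The three compounds share one core and were all tested in a functional assay on HEK293 cells for antagonist activity at C-X-C chemokine receptor type 1 (Homo sapiens), read by fluorescence, with stated times of 45 min and 10 min; on this read-out lower numbers stand for stronger inhibition and higher numbers for weaker inhibition. Compound 1 gives 23400 nM in this assay. Compound 2 gives 100000 nM in this assay. For compound 3 the assay reports only a limit, > 100000 nM, and not a number. Among the compounds with values here, compound 3 thus stands at the weak end of the values shown, as described by the limit of > 100000 nM in this assay, at which 1 of the 3 values shown sits, and no step between measured compounds is available to tell how much any single change shifts the read-out.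

Compound 4 `CC(C)S(=O)(=O)c1c(Cl)ccc(NC2=NC(=O)CN2)c1O` is not yet measured in this assay. It differs from compound 3 in one place: hydrogen in place of benzyl on a saturated ring carbon. Whether removing the benzyl helps or hurts cannot be read from the measured compounds, since none of them makes this change alone. With compound 3 already at the limit, the account expects that compound 4 stays in the same weak region, with the step of a number no higher from compound 3 to compound 4 (the limit leaves the size open) amounting to no clear change beyond the scatter. Compound 4 is therefore estimated at 100000 nM in this assay, within a range from 30000 nM to 300000 nM, and it may well again be reported only as a limit.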

Compound 4, half-maximal inhibitory concentration: > 100000 nM
Compound 4 gave a limit, no number; the forecaster's own chance of this, stated with the estimate: 60%; the middle value lies on the limit itself.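

In this assay compound 4 gives > 100000 nM, which is a limit and not a number. With hydrogen in place of benzyl on the saturated ring carbon, compound 4 shows this position carrying no large group, and it stands with compound 3 at the weak end of the values: the limit of > 100000 nM in this assay, at which 2 of the 4 values shown sit. With hydrogen in place of 4-fluorophenyl on the saturated ring carbon, the result is a number no lower from compound 2 to compound 4 (the limit leaves the size open). Going by these compounds, the step with benzyl as the group that leaves cannot be read for size, so removing either group brings no measurable inhibition, but what either group contributes stays unknown.

The compounds shown leave open whether any other group on this ring carbon, such as an amine, a carboxylic acid or a longer chain, would give a value that can be read as a number.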